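Carboxyphenyl sulfoxide series: shifting the carboxyl position

This account rests on a few compounds, and the source may have more. Where it says the series, first, only, none or still open, it means among the compounds named here.

For the measured compounds named here, compound 2 `CCCCCCCCCCCCOc1ccc(C[S+]([O-])c2ccc(C(=O)O)cc2)nc1/C=C/C(=O)O` gives the lowest number of the two measured so far; in an assay for binding affinity to leukotriene B4 receptor 1 (Homo sapiens) (a lower number here means a stronger inhibitor, a higher number a weaker inhibitor), compound 2 gives 252 nM. Its nearest neighbour is compound 1 `CCCCCCCCCCCCOc1ccc(COc2cccc(C(=O)O)c2)nc1/C=C/C(=O)O`, which in this assay gives 1130 nM; the step of a 4.5-fold lower number from compound 1 to compound 2 (0.65 log units; beyond the scatter) is the only measured one in the set.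

Compound 3 `CCCCCCCCCCCCOc1ccc(C[S+]([O-])c2ccccc2C(=O)O)nc1/C=C/C(=O)O` differs from compound 2 in one place: 2-carboxyphenyl in place of 4-carboxyphenyl on a sulfur. Going by the values given here, no measured step isolates a shift of the carboxyl around the ring; the single step from compound 1 to compound 2 changed the link to the ring and the carboxyl position together, so it bears on the present change only loosely. With nothing in the data pointing in either direction, the expectation for compound 3 in this assay is a step of a 1.8-fold higher number from compound 2 to compound 3 (0.25 log units; within the scatter), which sits near the edge of the scatter, with a wide range. The estimate for compound 3 is 450 nM, between 120 nM and 1700 nM.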

Compound 3, inhibition constant: 478 nM
The estimate for compound 3 lay 1.1-fold (0.03 log units) below the measured number, within the range that was stated.
By their numbers in this assay, from the lowest: compounds 2 and 3 (each within the scatter of the next); then compound 1.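

In this assay, a 1.9-fold higher number from compound 2 to compound 3 (0.28 log units; within the scatter) means that 2-carboxyphenyl and 4-carboxyphenyl on this sulfur cannot be told apart, so this shift of the carboxyl has no effect that can be read beyond the scatter. The second sulfoxide also keeps its distance from the starting compound, a 2.4-fold lower number from compound 1 to compound 3 (0.37 log units; beyond the scatter), and both sulfoxides now give lower numbers than compound 1, with no compound shown going against this. No supporting data on either step bear on the reason for these results.

Which part of the group on the saturated chain carbon accounts for the gap to compound 1 stays open, as both steps from it replace that whole group. As far as these compounds go, how a tetrazole in place of the carboxylic acid, or an unsubstituted phenyl on the sulfur, would read in this assay is also open.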